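From a chlorinated ring to a short chain on the carbonyl

The compounds below may be only part of what the source reports. "The series", "measured", "known", "first", "only" and "open" are said of these compounds alone.

Compound 1 `COc1ccc(NC(=O)C2CCc3ccccc3N2)cc1` gives 38000 nM in a functional assay on ACHN cells (Homo sapiens) for cytotoxicity, read by sulforhodamine B assay, with a stated time of 72 h; on this read-out lower numbers stand for stronger inhibition of growth and higher numbers for weaker inhibition of growth.
Compound 2 `CC(=O)N1c2ccccc2CCC1C(=O)Nc1cc(C(F)(F)F)cc(C(F)(F)F)c1` reaches only the assay limit of > 70000 nM, not a number.
Compound 3 `O=C(Nc1cc(C(F)(F)F)cc(C(F)(F)F)c1)C1CCc2ccccc2N1C(=O)c1cccc(Cl)c1` gives 813 nM.

Compound 3 therefore holds the lowest of the two numbers shown, with compound 1 far above it, well beyond the usual scatter. Compound 4 `CCCC(=O)N1c2ccccc2CCC1C(=O)Nc1cc(C(F)(F)F)cc(C(F)(F)F)c1` keeps the whole of compound 3 except for one change: propyl in place of 3-chlorophenyl on a carbonyl carbon. Going by the values given here, the only measured step that speaks to this place is the one where a small methyl grew into the same chlorinated ring, an at least 86-fold lower number from compound 2 to compound 3 (1.93 log units; beyond the scatter). Compound 4 partly walks that change back, trading the ring for a three-carbon chain that is larger than methyl but has no ring at all. Its number is therefore expected to rise, probably sharply, back toward where compound 2 sits, while the extra length of the chain may keep it short of the limit. For compound 4 the expected value is 15000 nM, with a plausible range from 3000 nM to 70000 nM, a step of an 18-fold higher number from compound 3 to compound 4 (1.27 log units; beyond the scatter).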

Compound 4, concentration for 50% growth inhibition: 13900 nM
Estimate against measurement, compound 4: 1.1-fold (0.03 log units) above, and the stated range covers the measured number.
By their numbers in this assay, from the lowest: compound 3; then compound 4; then compound 1. At a limit, above all of these: compound 2.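

In this assay, putting propyl in place of 3-chlorophenyl on this carbonyl carbon gives a 17-fold higher number from compound 3 to compound 4 (1.23 log units; beyond the scatter), so a three-carbon chain does not match the chlorinated ring at this position. The chain still counts for something, however: the step between the two chains reads an at least 5.0-fold lower number from compound 2 to compound 4 (0.70 log units; beyond the scatter), which shows that part of the gain seen with the ring can be reached with no ring at all. The value for compound 2 is a limit and not a number: the limit of > 70000 nM in this assay, at which 1 of the 4 values shown sits.

On these data alone, it remains open whether the advantage of compound 3 comes from the ring itself or from its chlorine, a question that plain phenyl on the same carbonyl carbon would address. Also open, as far as these compounds go, is whether a longer chain such as hexyl, or a saturated ring such as cyclohexyl, would narrow the remaining gap.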